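The source may report more compounds than this note shows. Statements on the series, on what has been measured and on what is new or still open speak of the compounds shown alone.

In a functional assay on A549 cells (Homo sapiens) for antiproliferative activity, read by MTT assay, with a stated time of 48 h (on this read-out higher numbers stand for weaker inhibition and lower numbers for stronger inhibition), compound 1 `CO[C@]1(C)/C=C/C(=O)/C(CO)=C\C[C@](C)(CCC=C(C)C)/C=C/[C@H]1OC(=O)C=C(C)C` gives 14400 nM and compound 2 `C=C1/C=C/C(=O)/C(CO)=C\C[C@](C)(CCC=C(C)C)/C=C/[C@H]1OC(=O)C=C(C)C` gives 3090 nM on the same read-out. Compound 3 `CC(C)=CCC[C@]1(C)/C=C/[C@@H](OC(=O)C=C(C)C)[C@](C)(O)/C=C/C(=O)/C(C(=O)O)=C\C1` stands only at a limit of the assay (> 10000 nM). Compound 4 `CC(C)=CCC[C@]1(C)/C=C/[C@@H](OC(=O)C=C(C)C)[C@](C)(O)/C=C/C(=O)/C(CN2CCCC2)=C\C1` carries (pyrrolidin-1-yl)methyl in place of carboxy on a double-bonded ring carbon. The carboxy group is absent from compound 2 (3090 nM) and from compound 1 (14400 nM), so a move away from it is expected to give a number within that span. The expected step (an at least 1.6-fold lower number from compound 3 to compound 4 (0.22 log units; that floor lies within the scatter)) is toward stronger inhibition and modest in size, though its size stays uncertain while compound 3 has no number. For compound 4 the estimated value is 6000 nM with an expected range from 2000 nM to 18000 nM.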

Compound 4, half-maximal inhibitory concentration: 180 nM
For compound 4 the middle estimate is 33-fold (1.52 log units) above the measured one; measured number below the stated range.
By their numbers in this assay, from the lowest: compound 4; then compound 2; then compound 1.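

In this assay, (pyrrolidin-1-yl)methyl in place of carboxy on the double-bonded ring carbon gives an at least 55-fold lower number from compound 3 to compound 4 (1.74 log units; beyond the scatter). Going by these compounds alone, this is the first one-place comparison, and it shows that the group at this ring carbon can shift the read-out strongly toward stronger inhibition. The step is only a floor, as compound 3 stands at a limit of the assay: the limit of > 10000 nM in this assay, at which 1 of the 4 values shown sits.

This single pair cannot separate the loss of carboxy from the entry of the pyrrolidine ring. An open-chain amine such as diethylaminomethyl, or morpholin-4-ylmethyl, at the same ring carbon on this core would bear on that question.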